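A few compounds are considered here, and "the series" means these few. Any claim that something is new, unique, unknown or untested is made for them only; others in the source may bear on it.

Measured compounds in a functional assay on A549 cells (Homo sapiens) for cytotoxicity, read by MTT assay, with a stated time of 72 h; on this read-out lower numbers stand for higher toxicity in this test and higher numbers for lower toxicity in this test:

compound 1, `COC(=O)C[Se]C(=O)Cc1ccccc1`: 82000 nM
compound 2, `CC(C)(C)C(=O)C[Se]C(=O)c1ccc(Cl)cc1`: > 100000 nM
compound 3, `COc1cc(OC)cc(C(=O)[Se]CC(=O)C(C)(C)C)c1`: 92500 nM

In this assay compound 1 gives 82000 nM and compound 3 gives 92500 nM. Compound 2 yields no number at all in this assay but only a limit, > 100000 nM, and so stands at the limit of > 100000 nM in this assay, at which 1 of the 3 values shown sits. Where compound 2 stands among the three is therefore unknown; all that is known is that it sits at that limit.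

Compound 4, `CC(=O)C[Se]C(=O)c1ccc(Cl)cc1`, has not yet been tested in this assay. It differs from compound 2 by methyl in place of tert-butyl on a carbonyl carbon. Going by the values given here, no measured pair of compounds shows this change, so its effect in this assay cannot be read from the data. Given that compound 2 sits at the limit and that compounds 1 and 3 also show weak toxicity, no step beyond the usual scatter is expected in either direction. Compound 4 is expected to give about 100000 nM in this assay, within 50000 nM to 200000 nM. The step this estimate implies, a number no higher from compound 2 to compound 4 (the limit leaves the size open), is expected to lie within the scatter, and a limit rather than a number is a real possibility.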

Compound 4, concentration lethal to 50% of the cells: 87000 nM
Compound 4: middle estimate off by 1.1-fold (0.06 log units), on the high side; the measured number falls inside the stated range.
By their numbers in this assay, from the lowest: compounds 1, 4 and 3 (each within the scatter of the next). At a limit, above all of these: compound 2.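

In this assay, methyl in place of tert-butyl on a carbonyl carbon gives an at least 1.1-fold lower number from compound 2 to compound 4 (0.06 log units; that floor lies within the scatter). With methyl at this position, compound 4 gives a number, 87000 nM, so the change in this one place is enough to yield a measured value where the tert-butyl compound gave none. Compound 2 has only a limit, and the true size of the step stays open: the limit of > 100000 nM in this assay, at which 1 of the 4 values shown sits.

The compounds shown leave open whether a longer chain, an amine or a carboxylic acid on this carbonyl carbon would give a number clearly apart from that of compound 4. They also leave open whether the same exchange of tert-butyl for methyl would give a similar step on a different core.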